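This account rests on a few compounds, and the source may have more. Where it says the series, first, only, none or still open, it means among the compounds named here.

Compound 1 `CC(=O)/C(=C\c1c(-c2ccccc2)[nH]c2ccccc12)S(=O)(=O)c1ccccc1` and compound 2 `Cc1ccc(S(=O)(=O)/C(C#N)=C/c2c(-c3ccccc3)[nH]c3ccccc23)cc1` share one core and differ in more than one place. In a functional assay on MT4 cells (Homo sapiens) for antiproliferative activity, read by MTT assay, with a stated time of 96 h (a higher number here means that more compound is needed for the effect, a lower number that less compound is needed), compound 1 gives 400 nM and compound 2 gives 400 nM, so compound 2 stands level with compound 1 within the scatter. Compound 3 `N#C/C(=C\c1c(-c2ccccc2)[nH]c2ccccc12)S(=O)(=O)c1ccccc1` is reached from compound 2 by a single change: hydrogen in place of methyl on an aromatic carbon, para to a large group. Because compound 1 gives 400 nM while compound 2 gives 400 nM despite a larger difference, the step of no change at the digits printed from compound 2 to compound 3 (within the scatter) is expected to stay within the scatter. Compound 3 is estimated at 400 nM, between 200 nM and 800 nM.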

Compound 3, half-maximal effective concentration: 400 nM
Compound 3: middle estimate and measured number agree at the digits printed; the range from low to high includes it.
By their numbers in this assay, from the lowest: compounds 1, 2 and 3 (each within the scatter of the next).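

In this assay, the change of 4-methylphenyl to phenyl gives no change at the digits printed from compound 2 to compound 3 (within the scatter), so the methyl can be lost from this ring without a visible effect. Cyano in place of acetyl gives no change at the digits printed from compound 1 to compound 3 (within the scatter) and now isolates that swap, which the first pair mixed with the methyl difference. No measured evidence offers a reason for either result.

Only hydrogen and methyl are compared on the ring, and only cyano and acetyl on the chain carbon. On these data alone, whether an amine or a carboxylic acid at either place would keep this level stays open.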